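The source may report more compounds than this note shows. Statements on the series, on what has been measured and on what is new or still open speak of the compounds shown alone.

Compound 1 `CCCCc1nc(N)nc(N)c1-c1ccc(Cl)cc1` gives in an assay for inhibition of beta-N-acetyl-D-hexosaminidase-A/B (Homo sapiens) (on this read-out lower numbers stand for stronger inhibition and higher numbers for weaker inhibition), a reading of > 1400000 nM, which is a limit of the measurement rather than a number.
Compound 2 `CCc1nc(N)nc(N)c1-c1ccccc1C` gives 43000 nM in this assay.
Compound 3 `CCCc1nc(N)nc(N)c1-c1ccc(Cl)cc1` gives 18000 nM in this assay.

Of the two real numbers, compound 3 has the lower one; compound 2 sits above it by more than the usual scatter. Compound 4 `CC(C)c1nc(N)nc(N)c1-c1ccc(Cl)cc1` differs from compound 3 by isopropyl in place of propyl on an aromatic carbon. Among the compounds with values here, the only measured step touching this place, an at least 77-fold lower number from compound 1 to compound 3 (1.89 log units; beyond the scatter), shortened the chain and gave a large change, whereas here the chain keeps its size and is only rearranged, so that step guides only loosely. A step expected to stay near the scatter, perhaps slightly toward weaker inhibition, is a 1.4-fold higher number from compound 3 to compound 4 (0.14 log units; within the scatter). Compound 4 is therefore estimated at 25000 nM, within a range from 8000 nM to 80000 nM.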

Compound 4, half-maximal inhibitory concentration: > 410000 nM
Compound 4 ended at the assay's limit; the forecaster's own chance of this, stated with the estimate: 5%; at least 16-fold (1.21 log units) between middle value and limit.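

Propyl and isopropyl hold the same atoms, yet on this aromatic carbon the rearrangement alone gives an at least 22-fold higher number from compound 3 to compound 4 (1.35 log units; beyond the scatter). Within the data shown here, the earlier compounds showed only that chain length matters at this place in this assay; now the arrangement of a chain of unchanged size matters too. The reading for compound 4 is a limit, so the full size of this step stays unknown, and the step between compound 1 and compound 4 cannot be read: the limit of > 410000 nM in this assay, at which 1 of the 4 values shown sits.

The compounds shown leave open how a cyclopropyl group, or a straight chain carrying an amine, would read on this carbon.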